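Inverting one ring stereocentre in a malonamide integrin ligand

The source may report more compounds than this note shows. Statements on the series, on what has been measured and on what is new or still open speak of the compounds shown alone.

Of the compounds shown here, two have been measured in an assay on K562 cells for inhibition of integrin alpha-5/beta-1 (Homo sapiens); on this read-out lower numbers stand for stronger inhibition and higher numbers for weaker inhibition. Compound 1 `CCCN(C(=O)CC(=O)O)C1=C(C)CC(c2ccccc2)N(CCCCN)C1=O` gives 43 nM in this assay. Compound 2 `CCCN(C(=O)CC(=O)O)C1=C(C)C[C@@H](c2ccc(N)cc2)N([C@@H](C)c2ccc(OC)cc2)C1=O` is the more elaborate relative; in this assay compound 2 returns only a limit, > 1000000 nM, so its true value is not known. On the numbers shown, compound 2 therefore stands at the limit of > 1000000 nM in this assay, at which 1 of the 2 values shown sits, the weak end of the data, while compound 1 stands at a measured value.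

Compound 3 `CCCN(C(=O)CC(=O)O)C1=C(C)C[C@H](c2ccc(N)cc2)N([C@@H](C)c2ccc(OC)cc2)C1=O` has not yet been measured. It differs from compound 2 in this way: the two compounds have the same atoms and bonds and differ only in configuration as drawn: 1 of 2 stereo elements differ; a stereocentre at a saturated ring carbon is drawn S in compound 2 and R in compound 3. The two compounds share the same atoms and bonds and differ only in configuration as drawn; a stereocentre at a saturated ring carbon is drawn S in compound 2 and R in compound 3.

Within the data shown here, no measured pair in this set isolates such a change, so the size of the step is uncertain. Compound 2 sits at a limit in this assay. Compound 1, with the same core, reaches 43 nM in this assay. From these two results a large gain toward stronger inhibition is expected for the inverted stereocentre, a step of an at least 10000-fold lower number from compound 2 to compound 3 (4.00 log units; beyond the scatter). Compound 3 is estimated at 100 nM, within a range of 10 nM to 3000 nM.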

Compound 3, half-maximal inhibitory concentration: 18 nM
The estimate for compound 3 lay 5.6-fold (0.74 log units) above the measured number; measured number inside the range.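

In this assay, among these compounds, drawing the stereocentre at a saturated ring carbon as R rather than S gives an at least 55000-fold lower number from compound 2 to compound 3 (4.74 log units; beyond the scatter), and this is the first step in the set that isolates a single change. Compound 1 and compound 2 differ in several places at once, so they could not show how much this one centre matters; the pair of compound 2 and compound 3 assigns the whole step to it: the fact that compounds 2 and 3 differ only in the configuration as drawn. As far as these compounds go, the true size of the step remains unknown, as its weak end rests on a limit rather than a number: the limit of > 1000000 nM in this assay, at which 1 of the 3 values shown sits.

The compounds shown leave open whether the other stereocentre, drawn alike in compound 2 and compound 3, carries similar weight, and compound 1 is drawn without configuration at the ring carbon, so it cannot tell which form accounts for its value. They also leave open whether the preference for R holds when the amine on the phenyl ring is replaced by a guanidine, or when the group on the ring nitrogen is a longer chain ending in a guanidine.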